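A few compounds are considered here, and "the series" means these few. Any claim that something is new, unique, unknown or untested is made for them only; others in the source may bear on it.

In a functional assay on MES-SA/Dx5 cells (Homo sapiens) for inhibition, with a stated time of 72 h, in the presence of a further agent that is not named here (on this read-out lower numbers stand for stronger inhibition and higher numbers for weaker inhibition), compound 1 `COCc1cc(CN2CCCCC2)c(O)c2ncccc12` gives 7590 nM, compound 2 `CCOCc1cc(CN2CCCCC2)c(O)c2ncccc12` gives 7080 nM and compound 3 `CC(C)OCc1cc(CN2CCCCC2)c(O)c2ncccc12` gives 4370 nM. Compound 2 stands in the middle of these three numbers, and none of the gaps among them goes beyond the scatter.

Compound 4 `CCOCc1cc(CN2CCC(C)CC2)c(O)c2ncccc12` keeps the oxygen-bearing chain of compound 2 and changes the other substituent: methyl in place of hydrogen on a saturated ring carbon. In words, this is methyl in place of hydrogen on a saturated ring carbon, turning piperidin-1-yl into 4-methylpiperidin-1-yl.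

Among the compounds with values here, no measured step touches this ring, so the evidence is indirect. Small additions on the chain gave a 1.1-fold lower number from compound 1 to compound 2 (0.03 log units; within the scatter), a 1.6-fold lower number from compound 2 to compound 3 (0.21 log units; within the scatter) and a 1.7-fold lower number from compound 1 to compound 3 (0.24 log units; within the scatter). On these data alone, all three stay within the scatter, so no step beyond the scatter is expected in this assay, and the direction remains open, with only a slight lean towards lower numbers.

The estimated 1.2-fold lower number from compound 2 to compound 4 (0.07 log units; within the scatter) is correspondingly small. For compound 4 the expected value is 6000 nM, with an estimated range of 3000 nM to 12000 nM.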

Compound 4, half-maximal inhibitory concentration: 3020 nM
The estimate for compound 4 lay 2.0-fold (0.30 log units) above the measured number, and the stated range covers the measured number.
By their numbers in this assay, from the lowest: compounds 4, 3, 2 and 1 (each within the scatter of the next, the first and the last beyond it).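

In this assay the saturated ring carbon three ring bonds from the ring nitrogen responds to substitution: going from piperidin-1-yl to 4-methylpiperidin-1-yl gives a 2.3-fold lower number from compound 2 to compound 4 (0.37 log units; beyond the scatter) and is a modest step. The changes on the oxygen-bearing chain, a 1.1-fold lower number from compound 1 to compound 2 (0.03 log units; within the scatter) and a 1.6-fold lower number from compound 2 to compound 3 (0.21 log units; within the scatter) and a 1.7-fold lower number from compound 1 to compound 3 (0.24 log units; within the scatter), all stayed within the scatter, so this methyl is the first single change in the series shown to move the number beyond it. Nothing available explains why this methyl has this effect.

On these data alone, whether the same methyl gives a similar step on the chains of compound 1 and compound 3 remains open. Also open, as far as these compounds go, is how this ring carbon responds to an ethyl group, a hydroxyl group or a phenyl ring in place of the methyl.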